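This account rests on a few compounds, and the source may have more. Where it says the series, first, only, none or still open, it means among the compounds named here.

In a functional assay on HT-29 cells (Homo sapiens) for inhibition, read by MTT assay, with a stated time of 120 h (on this read-out lower numbers stand for stronger inhibition and higher numbers for weaker inhibition), compound 1 `CC(NC(=O)CCc1ccc(NC(=O)Nc2ccc(Cl)c(C(F)(F)F)c2)cc1)c1ccccc1` gives 26500 nM and compound 2 `O=C(CCc1ccc(NC(=O)Nc2ccc(Cl)c(C(F)(F)F)c2)cc1)NC1CCC1` gives 21300 nM as the half-maximal inhibitory concentration. Going by the values given here, these are the only two numbers so far, and they lie within the scatter of each other, so compound 2 stands level with compound 1. Compound 3 `CC1CN(C(=O)CCc2ccc(NC(=O)Nc3ccc(Cl)c(C(F)(F)F)c3)cc2)CC(C)O1` keeps the shared core and differs from compound 2 in one place, as 2,6-dimethylmorpholin-4-yl in place of cyclobutylamino on a carbonyl carbon shows: 2,6-dimethylmorpholin-4-yl sits in place of cyclobutylamino on a carbonyl carbon. Among the compounds with values here, one measured step bears on this, a 1.2-fold lower number from compound 1 to compound 2 (0.09 log units; within the scatter) with cyclobutyl in place of 1-phenylethyl on an amide-type nitrogen, and it stayed within the scatter. Within the data shown here, no measured compound carries 2,6-dimethylmorpholin-4-yl, so this is only a loose guide. No shift beyond the scatter, in either direction, is therefore expected in this assay with a 1.1-fold lower number from compound 2 to compound 3 (0.03 log units; within the scatter) as the estimated step. For compound 3 the estimated value is 20000 nM with 8000 nM to 50000 nM as its likely range.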

Compound 3, half-maximal inhibitory concentration: > 50000 nM
Compound 3 was reported as a limit (the forecaster's own chance of this, stated with the estimate: 15%); middle value at least 2.5-fold (0.39 log units) from the limit.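

In this assay compound 3 is reported only as a limit, not as a number: the limit of > 50000 nM in this assay, at which 1 of the 3 values shown sits. Even so, placing 2,6-dimethylmorpholin-4-yl on this carbonyl carbon instead of cyclobutylamino gives an at least 2.3-fold higher number from compound 2 to compound 3 (0.37 log units; beyond the scatter), the first change here to pass the scatter, and it also replaces a group with a hydrogen-bond donor by one with none. The comparison with the 1-phenylethyl amide is weaker, with an at least 1.8-fold higher number from compound 1 to compound 3 (0.27 log units; that floor lies within the scatter), so the clear evidence rests on the step from the cyclobutyl amide.

The compounds shown leave open how far compound 3 truly lies past the limit. They also leave open whether the loss of the amide hydrogen, the ring oxygen or the two methyl groups matters most, a question that morpholin-4-yl without the methyl groups or piperidin-1-yl would help to separate.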